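A few compounds are considered here, and "the series" means these few. Any claim that something is new, unique, unknown or untested is made for them only; others in the source may bear on it.

Compound 1 `C/C(=N\Nc1nc2ccccc2o1)c1cccnn1` and compound 2 `C/C(=N\Nc1nc2ccccc2o1)c1cccnc1` share one core and differ only in the ring on a carbon with a double bond to nitrogen. In a functional assay on HeLa cells (Homo sapiens) for antiproliferative activity, read by sulforhodamine B assay (on this read-out higher numbers stand for weaker inhibition and lower numbers for stronger inhibition), compound 1 gives 1180 nM. Compound 2 reaches only a limit of this assay, > 100000 nM. The step of an at least 84-fold higher number from compound 1 to compound 2 (1.92 log units; beyond the scatter) is large, and rests on (the limit of > 100000 nM in this assay, at which 1 of the 2 values shown sits). Compound 3 `C/C(=N\Nc1nc2ccccc2o1)c1ncccn1` differs from compound 2 by pyrimidin-2-yl in place of pyridin-3-yl on a carbon with a double bond to nitrogen. That single measured step, which removed one ring nitrogen, bears on this change, which restores a second ring nitrogen. Compound 3 is therefore expected to move back toward stronger inhibition, an at least 20-fold lower number from compound 2 to compound 3 (1.30 log units; beyond the scatter). Compound 3 is estimated at 5000 nM, between 800 nM and 100000 nM.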

Compound 3, half-maximal inhibitory concentration: 180 nM
For compound 3 the middle estimate is 28-fold (1.44 log units) above the measured one; measured number below the stated range.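

Putting pyrimidin-2-yl on this carbon with a double bond to nitrogen gives an at least 550-fold lower number from compound 2 to compound 3 (2.74 log units; beyond the scatter) in this assay, so the loss seen with pyridin-3-yl can be more than reversed. The size of this step is only a bound, since compound 2 stands at a limit: the limit of > 100000 nM in this assay, at which 1 of the 3 values shown sits. Two rings with 2 hetero atoms also differ from each other, with a 6.6-fold lower number from compound 1 to compound 3 (0.82 log units; beyond the scatter), so the count of hetero atoms alone does not settle the result. On these data alone, whether a pyrazin-2-yl or a plain phenyl ring would fit this picture remains open. So does the effect of adding an amine to the pyrimidin-2-yl ring.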